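The source may hold more compounds than are shown below. What is called first, only, known or untested is meant among the compounds shown, and "the series" means these compounds.

In a functional assay for agonist activity at Glucose-dependent insulinotropic receptor (Homo sapiens) (a lower number here means that less compound is needed, a higher number that more compound is needed for the effect), compound 1 `N#Cc1cnccc1COc1cnc(N2CCN(c3noc(C(F)(F)F)n3)CC2)nc1` gives 2 nM, and compound 2 `N#Cc1cnccc1COc1cnc(N2CCN(c3nc(C(F)(F)F)no3)CC2)nc1` gives 5.01 nM.

Compound 2 stands at the highest of the two numbers in this assay, with compound 1 the lower by a 2.5-fold higher number from compound 1 to compound 2 (0.40 log units; beyond the scatter). Compound 3 `N#Cc1cnccc1COc1cnc(N2CCN(c3nnc(C(F)(F)F)o3)CC2)nc1` differs from compound 2 by 5-(trifluoromethyl)-1,3,4-oxadiazol-2-yl in place of 3-(trifluoromethyl)-1,2,4-oxadiazol-5-yl on an amine nitrogen in a ring. Within the data shown here, only the step from compound 1 to compound 2 bears on this change, and it was modest in size. A step of similar modest size, in either direction or none beyond the scatter, is therefore expected for compound 3 in this assay, as a 1.2-fold higher number from compound 2 to compound 3 (0.08 log units; within the scatter). Compound 3 is estimated at 6 nM, within 2 nM to 20 nM.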

Compound 3, half-maximal effective concentration in the Glucose-dependent insulinotropic receptor assay: 25.1 nM
Estimate against measurement, compound 3: 4.2-fold (0.62 log units) below, outside the stated range (above it).
By their numbers in the Glucose-dependent insulinotropic receptor assay, from the lowest: compound 1; then compound 2; then compound 3.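

In the Glucose-dependent insulinotropic receptor assay, rearranging the same atoms on the amine nitrogen in a ring matters more than the first swap suggested: 5-(trifluoromethyl)-1,3,4-oxadiazol-2-yl gives a 5.0-fold higher number from compound 2 to compound 3 (0.70 log units; beyond the scatter) and a 13-fold higher number from compound 1 to compound 3 (1.10 log units; beyond the scatter). The isomer is therefore not a neutral replacement at this position, even though the counts of heavy atoms and hydrogen-bond acceptors stay the same. In a physicochemical assay for solubility, at pH 7.4 (on this read-out lower numbers stand for lower solubility and higher numbers for higher solubility), compound 2 gives 4800000 nM and compound 3 gives 120000 nM. The change also costs compound 3 ground against compound 2 in the physicochemical assay: the measured solubility of compound 2, 4800000 nM, and of compound 3, 120000 nM, a 40-fold lower number (1.60 log units; beyond the scatter)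

As far as these compounds go, it remains open how a 1,3,4-thiadiazole, or a methyl group in place of trifluoromethyl, would fare at this position on these two read-outs.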